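From Compound 3 to Compound 4, a Step Near the Limit

The source may hold more compounds than are shown below. What is called first, only, known or untested is meant among the compounds shown, and "the series" means these compounds.

In a functional assay on MCF cells (Homo sapiens) for antiproliferative activity, with a stated time of 72 h (on this read-out lower numbers stand for stronger inhibition and higher numbers for weaker inhibition), compound 1 (`OC[C@H]1O[C@@H](n2cnc3c(NCc4ccc(Cl)cc4Cl)ncnc32)[C@H](O)[C@@H]1O`) gives 127000 nM as a measured number. Compound 2 (`OC[C@H]1O[C@@H](n2cnc3c(NCc4ccc(F)cc4Cl)ncnc32)[C@H](O)[C@@H]1O`) gives > 166000 nM which is a limit. Compound 3 (`OC[C@H]1O[C@@H](n2cnc3c(NCc4ccc(F)c(Cl)c4)ncnc32)[C@H](O)[C@@H]1O`) gives > 166000 nM which is likewise a limit, so it stands at the limit of > 166000 nM in this assay, at which 2 of the 3 values shown sit, with no number of its own. Compound 4 (`OC[C@H]1O[C@@H](n2cnc3c(NCc4ccccc4OC(F)F)ncnc32)[C@H](O)[C@@H]1O`) carries 2-(difluoromethoxy)phenyl in place of 3-chloro-4-fluorophenyl (2-(difluoromethoxy)phenyl in place of 3-chloro-4-fluorophenyl on a saturated chain carbon bound to a nitrogen on an aromatic ring) on the same saturated chain carbon. Changes to this aromatic group gave an at least 1.3-fold higher number from compound 1 to compound 3 (0.11 log units; that floor lies within the scatter) and an at least 1.3-fold higher number from compound 1 to compound 2 (0.11 log units; that floor lies within the scatter) and also a step that the two limits leave unreadable from compound 2 to compound 3 so no step beyond the scatter is expected in this assay for this change. The expected step is a step that the limit leaves unreadable from compound 3 to compound 4 and nothing larger. Compound 4 is estimated at 170000 nM with 90000 nM to 320000 nM as its expected range.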

Compound 4, half-maximal inhibitory concentration: > 166000 nM
Compound 4: only a limit was reported; the forecaster's own chance of this, stated with the estimate: 70%; the middle value lies beyond the limit too.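

Compound 4 is the only one of the four compounds without chlorine on this aromatic group, yet 2-(difluoromethoxy)phenyl also yields only a limit in this assay: the limit of > 166000 nM in this assay, at which 3 of the 4 values shown sit.

Against compound 1, the one readable result is an at least 1.3-fold higher number from compound 1 to compound 4 (0.11 log units; that floor lies within the scatter), and the steps to compound 4 from compound 2 and compound 3 cannot be read.

As far as these compounds go, how far compound 2, compound 3 and compound 4 lie past their limits stays open. So does how an amine or a carboxylic acid on this aromatic ring, or a longer chain in place of the saturated chain carbon, would read in this assay.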